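Turning One Double Bond from Z to E

The source may report more compounds than this note shows. Statements on the series, on what has been measured and on what is new or still open speak of the compounds shown alone.

In a functional assay, read by spectrophotometry, with a stated time of 6 min (on this read-out higher numbers stand for an effect only at larger amounts of compound and lower numbers for an effect already at smaller amounts), compound 1 `COc1c(C)cc(O)cc1C/C=C(\C)CC(=O)/C=C(\C)CCCC(C)C(=O)/C=C/C(C)(C)O` gives 24500 nM. Compound 2 `COc1c(C)cc(O)cc1C/C=C(\C)CC(=O)/C=C(\C)CCCC(C)=O` gives 33300 nM, and compound 3 `COc1c(C)cc(O)cc1C/C=C(\C)CC(=O)/C=C(/C)CCCC(C)(O)C(=O)/C=C/C(C)(C)O` gives 43100 nM. The number for compound 3 lies within the usual scatter of the numbers for both other compounds, so these three results cannot be put in a firm order.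

Compound 4 `COc1c(C)cc(O)cc1C/C=C(\C)CC(=O)/C=C(\C)CCCC(C)(O)C(=O)/C=C/C(C)(C)O` has not yet been measured. Its relation to compound 3 is a matter of shape alone: the two compounds have the same atoms and bonds; at least one stereo element is drawn with a configuration in one of them and without one in the other: 1 of 4 stereo elements differ; a double bond is drawn Z in compound 3 and E in compound 4. The two compounds have the same atoms and bonds, and a double bond is drawn Z in compound 3 and E in compound 4.

Among the measured compounds shown here, only one measured step connects two compounds that differ in one place: a 1.4-fold higher number from compound 1 to compound 2 (0.13 log units; within the scatter). That step puts acetyl in place of 1-((3-hydroxy-3-methylbut-1-en-1-yl)carbonyl)ethyl, which is a different kind of change from the one at issue here. For the measured compounds named here, no measured pair isolates a switch between Z and E, so the evidence is indirect. Going by the values given here, still, the only measured step stays within the scatter, and all three numbers sit close together. The estimate is a 1.3-fold lower number from compound 3 to compound 4 (0.10 log units; within the scatter), so no step beyond the scatter is expected in this assay. For compound 4 the expected value is 34000 nM, with an estimated range from 18000 nM to 65000 nM.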

Compound 4, half-maximal effective concentration: 33100 nM
Compound 4: middle estimate off by 1.0-fold (0.01 log units), on the high side; the measured number falls inside the stated range.
By their numbers in this assay, from the lowest: compounds 1, 4, 2 and 3 (each within the scatter of the next).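

In this assay, the switch of one double bond from Z to E can now be read directly, and it stays within the scatter (a 1.3-fold lower number from compound 3 to compound 4 (0.11 log units; within the scatter)). Among the compounds shown here, compound 4 also gives the first reading of hydroxy in place of hydrogen on the saturated chain carbon bound to a carbonyl carbon and two saturated chain carbons (a 1.4-fold higher number from compound 1 to compound 4 (0.13 log units; within the scatter)), and of 1-hydroxy-1-((3-hydroxy-3-methylbut-1-en-1-yl)carbonyl)ethyl in place of acetyl (a 1.0-fold lower number from compound 2 to compound 4 (0.00 log units; within the scatter)), and both of these steps also stay within the scatter. None of these three changes therefore shifts the number beyond the scatter, although the reading of the double bond carries one reservation: (the fact that one of compounds 3 and 4 is drawn with a defined configuration and the other without, at the place where they differ).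

Going by these compounds, compound 1 and compound 4 carry only hydrogen or hydroxy on that saturated chain carbon, so the effect of an amine there remains open, as does the effect of a carboxylic acid in place of the acetyl of compound 2. Also open, on these data alone, is whether a switch from E to Z at the other double bonds of the chain would stay within the scatter in the same way.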